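Adenosine-like benzyl amines on G-361 cells

The source may hold more compounds than are shown below. What is called first, only, known or untested is meant among the compounds shown, and "the series" means these compounds.

Compound 1 `OC[C@H]1O[C@@H](n2cnc3c(NCc4ccccc4F)ncnc32)[C@H](O)[C@@H]1O` has no number of its own in a functional assay on G-361 cells (Homo sapiens) for antiproliferative activity, with a stated time of 72 h; on this read-out higher numbers stand for weaker inhibition and lower numbers for stronger inhibition: for compound 1 the entry reads "not determined" (no result reported), and one further entry, compound 2 `Cc1ccc(CNc2ncnc3c2ncn3[C@@H]2O[C@H](CO)[C@@H](O)[C@H]2O)cc1`, likewise reads "not determined" (no result reported). Within the data shown here, the only number in this assay comes from compound 3 `OC[C@H]1O[C@@H](n2cnc3c(NCc4ccc(Cl)c(Cl)c4)ncnc32)[C@H](O)[C@@H]1O`, which gives 145000 nM, a weak result. Compound 4 `OC[C@H]1O[C@@H](n2cnc3c(NCc4ccc(F)c(Cl)c4)ncnc32)[C@H](O)[C@@H]1O` differs from compound 1 by 3-chloro-4-fluorophenyl in place of 2-fluorophenyl on a saturated chain carbon bound to a nitrogen on an aromatic ring. Among the measured compounds shown here, with no measured step from compound 1 to lean on, the author expects compound 4 to land near compound 3 rather than to show any step beyond the scatter in this assay. Compound 4 is therefore estimated at 150000 nM, with a range from 40000 nM to 600000 nM, weak inhibition in this assay.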

Compound 4, half-maximal inhibitory concentration: > 166000 nM
Compound 4 gave a limit, no number; the forecaster's own chance of this, stated with the estimate: 30%; middle value at least 1.1-fold (0.04 log units) from the limit.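

In this assay compound 4 gives a limit and not a number: the limit of > 166000 nM in this assay, at which 1 of the 4 values shown sits. Fluoro in place of chloro on an aromatic carbon gives the first step that can be read here, an at least 1.1-fold higher number from compound 3 to compound 4 (0.05 log units; that floor lies within the scatter), so this floor does not separate the pair. Neither halogen in this place brings strong inhibition on these cells.

Going by these compounds, how far compound 4 truly lies from compound 3 stays open. So does whether an amine or a carboxylic acid on the phenyl ring, in place of either halogen, would move the result.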